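This account rests on a few compounds, and the source may have more. Where it says the series, first, only, none or still open, it means among the compounds named here.

Measured compounds:
- compound 1, `COc1cc(O)c2c(=O)cc(-c3ccccc3Cl)oc2c1CN1CCCCC1`: 118000 nM
- compound 2, `COc1cc(OC)c2c(=O)cc(-c3ccccc3Cl)oc2c1CN1CCCCC1`: 44200 nM
- compound 3, `CCN(CC)Cc1c(OC)cc(OC)c(C(=O)/C=C/c2ccccc2Cl)c1O`: 6700 nM

In a functional assay on Bel-7402 cells (Homo sapiens) for antiproliferative activity, with a stated time of 72 h (a higher number here means a weaker inhibitor, a lower number a stronger inhibitor), compound 3 gives the lowest number of the three. Compound 2 stands next to it with a higher number, and compound 1 is furthest away with the highest number of the set.

Compound 4, `COc1cc(OC)c(C(=O)/C=C/c2ccccc2Cl)c(O)c1CN1CCCC1`, shares its core with compound 3 and differs from it in one place: pyrrolidin-1-yl in place of diethylamino on a saturated chain carbon bound to an aromatic carbon. Of the measured compounds only compounds 1 and 2 form a pair differing in a single change, and that change, a 2.7-fold lower number from compound 1 to compound 2 (0.43 log units; beyond the scatter), concerns a methyl on an oxygen of a different core, not the amine of compound 3. For the measured compounds named here, no measured pair shows what exchanging one amine of five heavy atoms for another of five heavy atoms does here. The expectation is therefore a step within the scatter, with no clear direction, so compound 4 is expected to give about 6700 nM in this assay, with a range from 2500 nM to 18000 nM, meaning an expected step of no change at the digits printed from compound 3 to compound 4 (within the scatter).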

Compound 4, half-maximal inhibitory concentration: 6800 nM
Beside the measured number, compound 4's estimate is 1.0-fold (0.01 log units) below it; low and high end bracket the measured number.
By their numbers in this assay, from the lowest: compounds 3 and 4 (each within the scatter of the next); then compound 2; then compound 1.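

In this assay, replacing the open diethylamino with the ring of pyrrolidin-1-yl, on a saturated chain carbon bound to an aromatic carbon, gives a 1.0-fold higher number from compound 3 to compound 4 (0.01 log units; within the scatter) and so stays within the scatter. For the compounds shown here, this is the only measured pair that changes the amine, and it shows that in this one case, tying the same count of heavy atoms into a five-membered ring leaves the two numbers indistinguishable. No measurement shown here explains why these two amines read alike.

Open, on these data alone, is whether this position would give a similar number with morpholin-4-yl, which carries a ring oxygen, or with dipropylamino, which has longer chains on the nitrogen. Also open, as far as these compounds go, is whether pyrrolidin-1-yl would read the same way on the core of compound 2.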